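Fluoro for Chloro on a Cyano-Bearing Fused Core

This account rests on a few compounds, and the source may have more. Where it says the series, first, only, none or still open, it means among the compounds named here.

Of the compounds shown here, three built on closely related two-ring cores have been tested in a functional assay on A549 cells (Homo sapiens) for cytotoxicity, read by MTT assay; a higher number here means a weaker inhibitor, a lower number a stronger inhibitor. Compound 1, `N#Cc1c(Nc2ccccc2)c(Cl)c2nc(N)nc(N)c2c1F`, gives > 1000 ug/mL in this assay, which is a limit of the assay rather than a number. Compound 2, `N#Cc1c(Nc2ccccc2)c(F)c2nc(N)nc(N)c2c1F`, likewise reaches only the limit of > 1000 ug/mL in this assay. Compound 3, `N#Cc1c(NCc2ccccc2)c(Cl)c2nc(N)nc(N)c2c1NCc1ccccc1`, also stops at the limit of > 1000 ug/mL in this assay. The change from compound 1 to compound 2 is fluoro in place of chloro on an aromatic carbon, and the step it made is a step that the two limits leave unreadable from compound 1 to compound 2; both values are limits, so the size of the step is not readable, a point made by the limit of > 1000 ug/mL in this assay, at which 3 of the 3 values shown sit.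

Compound 4, `N#Cc1c(NCc2ccccc2)c(F)c2nc(N)nc(N)c2c1NCc1ccccc1`, is not yet measured. It differs from compound 3 by fluoro in place of chloro on an aromatic carbon. The difference between the core of compound 3 and the core of compound 1 is not broken down here. The change from compound 3 to compound 4 is the same kind of change as that from compound 1 to compound 2, but its surroundings differ: in compound 3 the carbon is ortho to a benzylamino group and para to a benzylamino group, whereas in compound 1 it is ortho to an anilino group and para to a fluoro group.

For compound 4 an estimate of 1000 ug/mL in this assay is expected, because compound 3 sits at > 1000 ug/mL and compound 2 at > 1000 ug/mL, both limits. The expected step is therefore a number no higher from compound 3 to compound 4 (the limit leaves the size open), most likely again only a limit.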

Compound 4, half-maximal inhibitory concentration: 13.9 ug/mL
Compound 4: the middle estimate sits 72-fold (1.86 log units) above what was measured, and the stated range ends above it.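

On the core that carries two benzylamino groups, fluoro in place of chloro on the aromatic carbon gives an at least 71-fold lower number from compound 3 to compound 4 (1.85 log units; beyond the scatter) in this assay, a large move towards stronger inhibition that rests on this single pair. Compound 3 gives > 1000 ug/mL, which is a limit and not a number, so the step has a lower bound but no fixed size. The result shows that this swap can matter greatly on one core, but it does not show that the gain carries over from one core to another, as the matching step on the core of compound 1 cannot be read because both of its values are limits: the limit of > 1000 ug/mL in this assay, at which 3 of the 4 values shown sit.

From the compounds shown here alone, only fluoro and chloro appear on this aromatic carbon, so it remains open whether a bromo or a methyl group there would also give a low number on the core with two benzylamino groups. Going by these compounds, it is also open whether the low number of compound 4 would survive if a longer chain, such as phenethylamino, took the place of the benzylamino groups.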